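Notes on the step from compound 2 to compound 3

The source may report more compounds than this note shows. Statements on the series, on what has been measured and on what is new or still open speak of the compounds shown alone.

- compound 1 `O=c1cc(N2CCN(CC3CCC(OS(=O)(=O)c4cccnc4)CC3)CC2)sc2c([N+](=O)[O-])cc(C(F)(F)F)cc12` gives > 64 ug/mL as a limit
- compound 2 `O=C(OC1CCC(CN2CCN(c3cc(=O)c4cc(C(F)(F)F)cc([N+](=O)[O-])c4s3)CC2)CC1)c1ccco1` gives > 64 ug/mL as a limit

In an ADME assay on Vero cells (Chlorocebus sabaeus) for cytotoxicity, read by MTT assay, with a stated time of 48 h (on this read-out higher numbers stand for weaker inhibition and lower numbers for stronger inhibition), compound 2 stands at > 64 ug/mL which is a limit and not a number. Compound 3 `COc1cccc(C(=O)OC2CCC(CN3CCN(c4cc(=O)c5cc(C(F)(F)F)cc([N+](=O)[O-])c5s4)CC3)CC2)c1` carries 3-methoxyphenyl in place of furan-2-yl on a carbonyl carbon. Within the data shown here, the only measured step bearing on this is a step that the two limits leave unreadable from compound 1 to compound 2 and it has no readable size. What the data offer is the limit of > 64 ug/mL in this assay, at which 2 of the 2 values shown sit, and nothing more. Given a step that the two limits leave unreadable from compound 1 to compound 2 no step beyond the scatter and no direction is expected in this assay for this change. The expected step is a step that the limit leaves unreadable from compound 2 to compound 3 in this estimate. For compound 3 the expected value is 70 ug/mL with an estimated range from 32 ug/mL to 128 ug/mL and a report as a limit is likely.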

Compound 3, half-maximal inhibitory concentration: > 64 ug/mL
Compound 3 gave a limit, no number (the forecaster's own chance of this, stated with the estimate: 75%); the middle value does not contradict the limit.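

In this assay, among these compounds, compound 3 gives > 64 ug/mL, which is a limit and not a number; no step among compound 1, compound 2 and compound 3 can be read. The compounds shown leave open the size and direction of any difference between these groups in this assay.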